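Adding a chloro group to compound 3

The compounds below may be only part of what the source reports. "The series", "measured", "known", "first", "only" and "open" are said of these compounds alone.

Values measured so far in a functional assay on NCI-H460 cells (Homo sapiens) for antiproliferative activity, read by sulforhodamine B assay, with a stated time of 72 h (on this read-out lower numbers stand for stronger inhibition and higher numbers for weaker inhibition), are these:
Compound 1 `O=C1CS/C(=N/Nc2nncc3ccccc23)N1c1ccccc1` gives 30 nM
Compound 2 `CCN1C(=O)CS/C1=N/Nc1nncc2ccccc12` gives 28 nM
Compound 3 `C(=C/c1ccccc1)\C(=N\Nc1nncc2ccccc12)c1ccccc1` gives 5.7 nM

Compound 3 has the lowest number of the three in this assay, and its gaps to compound 1 and to compound 2 both lie beyond the scatter. The next compound, compound 4 `Clc1ccc(C(/C=C/c2ccccc2)=N\Nc2nncc3ccccc23)cc1`, differs from compound 3 in one place: chloro in place of hydrogen on an aromatic carbon. In words, this is chloro in place of hydrogen on an aromatic carbon, para to a large group, which turns phenyl into 4-chlorophenyl.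

Among the compounds with values here, only one measured step links two compounds that differ in one place: a 1.1-fold lower number from compound 1 to compound 2 (0.03 log units; within the scatter). That step is ethyl in place of phenyl on an amide-type nitrogen in a ring, so it is a different exchange at a different place, and it bears on the present change only loosely. Within the data shown here, no measured compound shows what a chloro group does here, and the data give no direction. No step beyond the scatter is therefore expected in this assay. The expected step is a 1.0-fold lower number from compound 3 to compound 4 (0.02 log units; within the scatter), a size estimated from that single small step. For compound 4 the estimated value is 5.5 nM, with an expected range from 2 nM to 15 nM.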

Compound 4, half-maximal inhibitory concentration: 9.6 nM
For compound 4 the middle estimate is 1.7-fold (0.24 log units) below the measured one, and the stated range covers the measured number.
By their numbers in this assay, from the lowest: compounds 3 and 4 (each within the scatter of the next); then compounds 2 and 1 (each within the scatter of the next).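

In this assay, the exchange of hydrogen for chloro on an aromatic carbon, para to a large group, gives a step that does not separate the two compounds (a 1.7-fold higher number from compound 3 to compound 4 (0.23 log units; within the scatter)). Within the data shown here, until now, the only one-place comparison concerned an amide-type nitrogen in a ring, so this is the first reading on how the number responds to a change at this aromatic carbon: turning phenyl into 4-chlorophenyl leaves a difference no larger than repeated measurements of this kind would produce. No accompanying evidence bears on this result, so the comparison offers no account of it.

The compounds shown cover only this single substituent at this single place, so it remains open whether a group of a different kind there, such as an amine, a carboxylic acid or a longer chain, would give a step beyond the scatter. Also open, on these data alone, is whether chloro would behave in the same way on the other phenyl ring of the same molecule, or on a phenyl ring in a compound with a different core.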